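A few compounds are considered here, and "the series" means these few. Any claim that something is new, unique, unknown or untested is made for them only; others in the source may bear on it.

Measured so far in a functional assay on BE(2)-C cells (Homo sapiens) for inhibition, read by MTT assay, with a stated time of 72 h; a lower number here means a stronger inhibitor of growth, a higher number a weaker inhibitor of growth:
- compound 1, `O=S(=O)(NCCCNCc1ccc(Br)cc1)c1cc(C(F)(F)F)cc(C(F)(F)F)c1`, gives 2700 nM
- compound 2, `O=S(=O)(NCCCNCc1cccc(Cl)c1)c1cc(C(F)(F)F)cc(C(F)(F)F)c1`, gives 6900 nM

Among the compounds with values here, compound 2 stands highest of the two numbers in this assay; its nearest neighbour is compound 1, and the one measured step, a 2.6-fold higher number from compound 1 to compound 2 (0.41 log units; beyond the scatter), is modest but beyond the scatter. Compound 3, `COc1ccccc1CNCCCNS(=O)(=O)c1cc(C(F)(F)F)cc(C(F)(F)F)c1`, differs from compound 2 by 2-methoxyphenyl in place of 3-chlorophenyl on a saturated chain carbon bound to an amine nitrogen. Within the data shown here, the only measured step that bears on this position is a 2.6-fold higher number from compound 1 to compound 2 (0.41 log units; beyond the scatter), which exchanges one halogenated phenyl for another; no measured pair covers a 2-methoxyphenyl or any aryl carrying a hydrogen-bond acceptor at this place. Both measured numbers lie within a narrow band, so the expected step of a 1.2-fold lower number from compound 2 to compound 3 (0.06 log units; within the scatter) is taken to be small, of uncertain direction and not clearly beyond the scatter. Compound 3 is therefore estimated at 6000 nM in this assay, with a range expected from 2000 nM to 18000 nM.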

Compound 3, concentration for 50% growth inhibition: 3600 nM
Beside the measured number, compound 3's estimate is 1.7-fold (0.22 log units) above it; measured number inside the range.
By their numbers in this assay, from the lowest: compounds 1, 3 and 2 (each within the scatter of the next, the first and the last beyond it).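

In this assay, within the data shown here, 2-methoxyphenyl is the first group at this place, on a saturated chain carbon bound to an amine nitrogen, that carries no halogen, and the two new steps are a 1.9-fold lower number from compound 2 to compound 3 (0.28 log units; within the scatter) and a 1.3-fold higher number from compound 1 to compound 3 (0.12 log units; within the scatter). Neither step lies beyond the scatter, so among these three compounds a halogen on the phenyl is not needed to stay in the range set by the halogenated compounds, and the hydrogen-bond acceptor counted in the entering group brings no separation from either of them. Nothing available here bears on a cause for these steps.

As far as these compounds go, it remains open whether an unsubstituted phenyl, or a hydroxyl or carboxylic acid on the phenyl, would stay in this range. From the compounds shown here alone, the effect of a longer chain in the shared core is also open.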